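Furan-to-phenyl swap on the shared core

This account rests on a few compounds, and the source may have more. Where it says the series, first, only, none or still open, it means among the compounds named here.

Measured compounds:
compound 1 `Oc1cccc(-c2cc(-c3cccc(Cl)c3)nc(-c3ccco3)c2)c1` — 2460 nM
compound 2 `Oc1ccc(-c2cc(-c3cccc(Cl)c3)nc(-c3ccco3)c2)cc1` — 8020 nM

In a functional assay on HCT-15 cells (Homo sapiens) for cytotoxicity, read by CCK-8 assay and cell counting, with a stated time of 2 days (on this read-out lower numbers stand for stronger inhibition and higher numbers for weaker inhibition), compound 1 gives 2460 nM, the lowest of the two numbers recorded so far. For the measured compounds named here, compound 2 gives 8020 nM in this assay, and the single measured step, a 3.3-fold higher number from compound 1 to compound 2 (0.51 log units; beyond the scatter), concerns only the placement of the hydroxyl on the hydroxyphenyl group.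

Compound 3 `Oc1cccc(-c2cc(-c3ccccc3)nc(-c3cccc(Cl)c3)c2)c1` differs from compound 1 by phenyl in place of furan-2-yl on an aromatic carbon. Going by the values given here, no measured pair touches this change: the one step known in this assay leaves the furan-2-yl group in place on both sides, so it gives no guide to the direction or size of the swap. With nothing to support a shift either way, the expected step is a 1.0-fold higher number from compound 1 to compound 3 (0.01 log units; within the scatter), that is, none beyond the scatter, with a wide range to cover the lack of precedent. Compound 3 is therefore estimated at 2500 nM, expected to fall between 700 nM and 9000 nM.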

Compound 3, half-maximal inhibitory concentration: 2550 nM
Estimate against measurement, compound 3: 1.0-fold (0.01 log units) below; the range from low to high includes it.
By their numbers in this assay, from the lowest: compounds 1 and 3 (each within the scatter of the next); then compound 2.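

In this assay, the place next to the ring nitrogen accepts phenyl in place of furan-2-yl with no change beyond the scatter, with a 1.0-fold higher number from compound 1 to compound 3 (0.02 log units; within the scatter). For the compounds shown here, for this pair, neither the oxygen of furan-2-yl nor a five-membered aromatic ring is needed to keep the number at the level of compound 1, so the only step beyond the scatter remains the hydroxyl move, with a 3.3-fold higher number from compound 1 to compound 2 (0.51 log units; beyond the scatter). Nothing at hand explains why these two groups read alike.

Still open, as far as these compounds go, is whether this place also accepts a group other than an unsubstituted aromatic ring, such as an amine, a morpholine or a longer alkyl chain. Also open, from the compounds shown here alone, is whether the step from 3-hydroxyphenyl to 4-hydroxyphenyl keeps its size when phenyl replaces furan-2-yl.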